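Notes on the aryl methyl: compound 3 to compound 4

This account rests on a few compounds, and the source may have more. Where it says the series, first, only, none or still open, it means among the compounds named here.

The series shares one core, carried by compound 1 `Cc1ccccc1NC(=S)N/N=C/c1ccc2ccccc2n1`, compound 2 `FC(F)(F)c1ccccc1NC(=S)N/N=C/c1ccc2ccccc2n1` and compound 3 `Cc1cccc(NC(=S)N/N=C/c2ccc3ccccc3n2)c1`. In a functional assay on SGC-7901 cells (Homo sapiens) for antiproliferative activity, read by sulforhodamine B assay, with a stated time of 72 h (on this read-out higher numbers stand for weaker inhibition and lower numbers for stronger inhibition), compound 3 gives only a limit, > 100000 nM. Compound 1 likewise reaches only a limit in this assay, > 100000 nM. Compound 2 gives 20700 nM in this assay. The standing of compound 3 is thus that of the limit of > 100000 nM in this assay, at which 2 of the 3 values shown sit. The measured steps are an at least 4.8-fold lower number from compound 1 to compound 2 (0.68 log units; beyond the scatter) and a step that the two limits leave unreadable from compound 1 to compound 3; the first shows that exchanging the substituent on the aryl ring can move the number by an at least modest amount, the second gives no readable size. Compound 4 `S=C(N/N=C/c1ccc2ccccc2n1)Nc1ccccc1` differs from compound 3 by hydrogen in place of methyl on an aromatic carbon. Within the data shown here, no measured step removes a substituent outright, so the size of this step cannot be read from the data directly, and compound 3 itself gives no number. Compound 4 is therefore expected to stay near the limit, with an estimated 100000 nM and a range from 30000 nM to 300000 nM. The expected step is a number no higher from compound 3 to compound 4 (the limit leaves the size open), with no direction that can be trusted beyond the scatter.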

Compound 4, half-maximal inhibitory concentration: 26500 nM
Estimate against measurement, compound 4: 3.8-fold (0.58 log units) above; the measured number lies below the stated range.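

In this assay, hydrogen in place of methyl gives an at least 3.7-fold lower number from compound 3 to compound 4 (0.57 log units; beyond the scatter), and the same exchange on the 2-methylphenyl compound gives an at least 3.7-fold lower number from compound 1 to compound 4 (0.57 log units; beyond the scatter). Trifluoromethyl shows no separation from hydrogen, with a 1.3-fold higher number from compound 2 to compound 4 (0.11 log units; within the scatter). Compound 1 and compound 3 are the two compounds that reach only a limit of the assay: the limit of > 100000 nM in this assay, at which 2 of the 4 values shown sit.

Going by these compounds, the true numbers of compound 1 and compound 3 stay unknown, so the full size of the steps away from them is open and the step between them cannot be read. On these data alone, whether an amine, a methoxy group or a carboxylic acid on the phenyl ring would move the number away from that of compound 4 also remains open.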